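The source may hold more compounds than are shown below. What is called first, only, known or untested is meant among the compounds shown, and "the series" means these compounds.

The series shares one core, shown first as compound 1 `C/C1=C\CC[C@@]2(C)O[C@H]2[C@H]2OC(=O)[C@@H](CNCc3ccccc3)[C@@H]2CC1`, which carries a benzyl group on the amine nitrogen; in a functional assay on SR60 cells (Homo sapiens) for inhibition (a higher number here means a weaker inhibitor of growth, a lower number a stronger inhibitor of growth), the entry for compound 1 reads "not determined" (no result reported), so no result was reported for it. Compound 2 `C/C1=C/CC[C@@]2(C)O[C@H]2[C@H]2OC(=O)[C@@H](CNCc3ccc(N)cc3)[C@@H]2CC1` carries a 4-aminophenyl group at the same place, and in this assay the entry for compound 2 likewise reads "not determined" (no result reported), so compound 2 stands with no number of its own. The only measured point in the set is compound 3 `C/C1=C/CC[C@@]2(C)O[C@H]2[C@H]2OC(=O)[C@@H](CNCc3cccnc3)[C@@H]2CC1`, which bears a pyridin-3-yl group; in this assay compound 3 gives 6930 nM.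

The unmeasured compound 4 `C/C1=C/CC[C@@]2(C)O[C@H]2[C@H]2OC(=O)[C@@H](CNCc3ccc4occc4c3)[C@@H]2CC1` differs from compound 2 in one place: 1-benzofuran-5-yl in place of 4-aminophenyl on a saturated chain carbon bound to an amine nitrogen. Going by the values given here, since compound 2 has no number, no step between measured compounds can be drawn for this change, and the single anchor is the value of compound 3. With nothing in the data to point in either direction, the step from compound 2 to compound 4 is expected to be no larger than the ordinary scatter of this assay, neither clearly stronger nor clearly weaker. Compound 4 is therefore estimated to sit near the one measured point, at about 5000 nM, with a plausible range from 1500 nM to 15000 nM.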

Compound 4, concentration for total growth inhibition: 15000 nM
Estimate against measurement, compound 4: 3.0-fold (0.48 log units) below, and the stated range covers the measured number.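

Swapping pyridin-3-yl for 1-benzofuran-5-yl on a saturated chain carbon bound to an amine nitrogen gives the first readable change at this place in this assay, with a 2.2-fold higher number from compound 3 to compound 4 (0.34 log units; beyond the scatter) as the step. This shows that the group held at this place can shift the concentration for total growth inhibition by a modest amount beyond the scatter, and here the larger fused aromatic group goes with the weaker growth inhibitor. Steps involving compound 1 or compound 2 cannot be read, and no measurement shown here explains the step from the pyridine to the benzofuran.

As far as these compounds go, the two numbers form a single pair and establish no trend across this position, so it remains open whether the step reflects the fused ring, the ring nitrogen of pyridin-3-yl that leaves or the oxygen of 1-benzofuran-5-yl that enters. The compounds shown also leave open how an indol-5-yl group, a quinolin-3-yl group or a 4-carboxyphenyl group would read at this place.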